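Swapping Methylphenyl for Chlorophenyl on the Sulfonyl Group

The compounds below may be only part of what the source reports. "The series", "measured", "known", "first", "only" and "open" are said of these compounds alone.

Measured so far:
compound 1, `Cc1cccc(S(=O)(=O)NCc2ccc(CNC(=O)c3ccccc3C)cc2)c1`, 1000 nM
compound 2, `O=C(NCc1ccc(CNS(=O)(=O)c2ccc(Cl)cc2)cc1)c1cccnc1`, 1000 nM

The two tested compounds share a core carrying an amide on one side and a sulfonamide on the other. In an assay on MDA-MB-231 cells for displacement of a labelled ligand from C-X-C chemokine receptor type 4 (Homo sapiens), read by fluorescence and microscopy, with stated times of 10 min and 30 min (a higher number here means that more compound is needed for the effect, a lower number that less compound is needed), compound 1 gives 1000 nM. Compound 2, whose sulfonyl group carries a different aryl group and whose amide is built on a pyridine, gives in this assay a value of 1000 nM. Compound 1 therefore stands level with compound 2 at the digits given; the two cannot be told apart within the scatter of this kind of measurement.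

The compound still to be measured is compound 3, `Cc1ccccc1C(=O)NCc1ccc(CNS(=O)(=O)c2ccccc2Cl)cc1`. It differs from compound 1 in one place: 2-chlorophenyl in place of 3-methylphenyl on a sulfonyl sulfur. Going by the values given here, no pair among the tested compounds differs in a single place, so there is no measured step to borrow from, and the two values in hand sit at one common level. The expectation is a step of no real size, no change at the digits printed from compound 1 to compound 3 (within the scatter), well within the scatter. Compound 3 is accordingly estimated at 1000 nM, with a likely range from 300 nM to 3000 nM.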

Compound 3, effective concentration (reported as EC, without a stated level of effect): 1000 nM
Estimate against measurement, compound 3: no gap at the digits printed; the range from low to high includes it.
By their numbers in this assay, from the lowest: compounds 1, 2 and 3 (each within the scatter of the next).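

Going by these compounds alone, with 2-chlorophenyl in place of 3-methylphenyl on a sulfonyl sulfur, this assay shows no change at the digits printed from compound 1 to compound 3 (within the scatter) and so gives the first reading of a change made in a single place. Compound 2 could not give that reading, since it differs from compound 1 in more than one place; the new pair shows that this one exchange of aryl groups, both counted at the same number of heavy atoms, leaves the value where it was. Nothing measured here explains why the exchange leaves the value unmoved.

The exchange alters the ring's substituent and its numbered position together, so 3-chlorophenyl and 2-methylphenyl would be needed to take those two parts apart. With all the compounds shown at one level, it also remains open whether any group on the sulfonyl sulfur can move the value, for instance a ring bearing a carboxylic acid or an amine, or a longer chain in place of the aryl ring.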